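A few compounds are considered here, and "the series" means these few. Any claim that something is new, unique, unknown or untested is made for them only; others in the source may bear on it.

Compound 1 `Cc1ccc2nc(NC(=O)c3cn(-c4ccccc4)nc3-c3ccccc3)sc2c1` gives > 50000 nM in an ADME assay on HEK-293T cells (Homo sapiens) for cytotoxicity, read by MTT assay, with a stated time of 72 h (on this read-out higher numbers stand for weaker inhibition and lower numbers for stronger inhibition), which is a limit of the assay. Compound 2 `O=C(Nc1nc2ccccc2s1)c1cn(-c2ccccc2)nc1-c1ccc(Cl)cc1` gives 39600 nM. Compound 3 `O=C(Nc1nc2ccc(F)cc2s1)c1cn(-c2ccccc2)nc1-c1ccc(Cl)cc1` gives > 50000 nM, again a limit.

Compound 3 therefore stands at a limit rather than at a number, and only compound 2 has a measured value in this assay. For the measured compounds named here, the single measured step, an at least 1.2-fold higher number from compound 2 to compound 3 (0.10 log units; that floor lies within the scatter), ends at that limit (the limit of > 50000 nM in this assay, at which 2 of the 3 values shown sit). Compound 4 `Cc1ccc2nc(NC(=O)c3cn(-c4ccccc4)nc3-c3ccc(Cl)cc3)sc2c1` differs from compound 3 by methyl in place of fluoro on an aromatic carbon. Going by the values given here, no measured step covers this exchange. Compound 1, which carries the same 6-methyl-1,3-benzothiazol-2-yl, also sits at a limit. Compound 4 is thus expected to show no step beyond the scatter, a number no higher from compound 3 to compound 4 (the limit leaves the size open), most likely as a further limit. The estimate for compound 4 in this assay is 50000 nM, between 30000 nM and 100000 nM.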

Compound 4, half-maximal inhibitory concentration: 35600 nM
Compound 4: middle estimate off by 1.4-fold (0.15 log units), on the high side; the measured number falls inside the stated range.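

In this assay, methyl in place of hydrogen at this position of the benzothiazole stays within the scatter: a 1.1-fold lower number from compound 2 to compound 4 (0.05 log units; within the scatter). Methyl in place of fluoro gives an at least 1.4-fold lower number from compound 3 to compound 4 (0.14 log units; that floor lies within the scatter), and chloro in place of hydrogen, with the methyl kept, gives an at least 1.4-fold lower number from compound 1 to compound 4 (0.14 log units; that floor lies within the scatter); each starts from a limit, so each is only a floor. Compound 1 and compound 3 each remain a limit: the limit of > 50000 nM in this assay, at which 2 of the 4 values shown sit.

Going by these compounds, how fluoro truly compares with hydrogen or methyl here stays open. So does the read-out with an amine or a carboxylic acid at this position.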